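Aryloxy variation on the diamino core, growth inhibition notes

A few compounds are considered here, and "the series" means these few. Any claim that something is new, unique, unknown or untested is made for them only; others in the source may bear on it.

Measured so far in a functional assay on CAKI-1 cells (Homo sapiens) for inhibition, read by sulforhodamine B assay, with a stated time of 48 h; on this read-out lower numbers stand for stronger inhibition of growth and higher numbers for weaker inhibition of growth:
compound 1, `Nc1cc(N)c2nc(-c3ccccc3)c(Oc3ccc(Cl)c(Cl)c3)nc2c1`: < 100000 nM
compound 2, `CCOC(=O)[C@H](CCC(=O)O)NC(=O)c1ccc(CNc2nc3cc(N)cc(N)c3nc2-c2ccccc2)cc1`: < 100000 nM
compound 3, `COc1cc(CNc2nc3cc(N)cc(N)c3nc2-c2ccccc2)cc(OC)c1OC`: 8710 nM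

Compound 1 carries a 3,4-dichlorophenoxy group on the shared core; in this assay compound 1 returns only a limit, < 100000 nM, and not a number. Compound 2 likewise stands at a limit, < 100000 nM. Going by the values given here, compound 3, which bears a benzylamino group instead of an aryloxy group, is the only member with a definite figure, 8710 nM. Two of the three values therefore sit at the same edge of the measurable range, as noted: the limit of < 100000 nM in this assay, at which 2 of the 3 values shown sit. Where compound 1 stands relative to compound 3 cannot be told from a limit alone.

Compound 4, `Nc1cc(N)c2nc(-c3ccccc3)c(Oc3ccc(F)cc3)nc2c1`, is the next member to be measured. It differs from compound 1 by 4-fluorophenyl in place of 3,4-dichlorophenyl on an oxygen on an aromatic ring, in words: 4-fluorophenyl in place of 3,4-dichlorophenyl on an oxygen on an aromatic ring. Among the compounds with values here, no measured pair carries a change of this kind, and the starting point is itself a limit, so the step from compound 1 to compound 4 is expected to be a step that the limit leaves unreadable from compound 1 to compound 4, with no direction claimed beyond the scatter. For compound 4 the estimate is 25000 nM, within 4000 nM to 100000 nM, with a fair chance that this assay again reports only a limit.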

Compound 4, concentration for total growth inhibition: 24500 nM
Beside the measured number, compound 4's estimate is 1.0-fold (0.01 log units) above it; the measured number falls inside the stated range.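

In this assay compound 1 gives only the limit < 100000 nM and not a number. Going by these compounds alone, no step from compound 1 to compound 4 can be read, in size or in direction. Whether 4-fluorophenyl in place of 3,4-dichlorophenyl on this oxygen changes growth inhibition at all remains open in the compounds shown.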